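A few compounds are considered here, and "the series" means these few. Any claim that something is new, unique, unknown or untested is made for them only; others in the source may bear on it.

Values in a functional assay on MCF7 cells (Homo sapiens) for antiproliferative activity, read by MTT assay, with a stated time of 72 h (a lower number here means a stronger inhibitor, a higher number a weaker inhibitor), for the series so far:
Compound 1 (`O=C(Nc1ccc(Cl)c(-c2nnc3c(Cl)cccn23)c1)c1ccc(C(F)(F)F)cc1Cl`): 81600 nM
Compound 2 (`O=C(Nc1ccc(Cl)c(-c2nnc3c(Cl)cccn23)c1)c1ccc(Cl)cc1`): 58400 nM

Compound 2 at 58400 nM and compound 1 at 81600 nM stand within the scatter of each other, so the numbers give compound 2 no separate place in the series. Compound 3 (`O=C(Nc1ccc(Cl)c(-c2nnc3c(Cl)cccn23)c1)c1cccnc1Cl`) has not yet been measured. It carries 2-chloropyridin-3-yl in place of 4-chlorophenyl on a carbonyl carbon, which gives one six-membered aromatic ring with 1 hetero atom where compound 2 has a ring of carbon only.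

Among the measured compounds shown here, no two measured compounds differ in one place, so no direct step guides this change. The only available reference is the pair of close values already noted, which share the core and differ in the group on the carbonyl carbon. In this assay no step beyond the scatter is expected, and any small drift is expected towards a higher number. The estimated value for compound 3 is 70000 nM with an expected range from 30000 nM to 150000 nM for the coming measurement. This estimate amounts to an expected 1.2-fold higher number from compound 2 to compound 3 (0.08 log units; within the scatter) in the series.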

Compound 3, half-maximal inhibitory concentration: > 100000 nM
Compound 3 gave a limit, no number; the forecaster's own chance of this, stated with the estimate: 20%; middle value at least 1.4-fold (0.15 log units) away from the limit.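

In this assay compound 3 gives > 100000 nM, which is a limit of the assay and not a number. Among the compounds shown here, the replacement of 4-chlorophenyl by 2-chloropyridin-3-yl on a carbonyl carbon is the first single-place change that can be read, and it gives an at least 1.7-fold higher number from compound 2 to compound 3 (0.23 log units; that floor lies within the scatter); this is only a floor, so the true size of the step remains unknown and could lie within the scatter or beyond it. What the change does show is that a six-membered aromatic ring with a hetero atom at this place, carrying chlorine as named, gives no reading lower than that of the all-carbon ring, and the reading here is bounded on one side only: the limit of > 100000 nM in this assay, at which 1 of the 3 values shown sits.

The step changes the ring atoms and the numbered place of the chlorine together, so the compounds shown do not separate the two, and a 2-chlorophenyl group on the same carbonyl carbon would be the comparison that bears on this. Also open, on these data alone, is how this place responds to other groups on the ring, such as an amine or a carboxylic acid.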